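Replacing One Aryl Arm on a Shared Core

The compounds below may be only part of what the source reports. "The series", "measured", "known", "first", "only" and "open" are said of these compounds alone.

Compound 1 `COc1ccc(Nc2ccc3cc(NC(=O)c4ccc(OC(C)=O)c(CC=C(C)C)c4)c(=O)oc3c2C)cc1` gives > 100000 nM in a functional assay on MCF7 cells (Homo sapiens) for antiproliferative activity (a lower number here means a stronger inhibitor, a higher number a weaker inhibitor), which is a limit of the assay rather than a number. Compound 2 `COc1ccc(Nc2ccc3cc(NC(=O)c4ccc(O)c(CC=C(C)C)c4)c(=O)oc3c2C)cc1` gives > 100000 nM in this assay, again only a limit. Compound 3 `COc1ccc(Nc2ccc3cc(NC(=O)c4ccc(OC)c(-c5cccc(OC)c5)c4)c(=O)oc3c2C)cc1` gives > 100000 nM in this assay, also a limit.

Compound 2 therefore stands where every measured compound stands: at the limit of > 100000 nM in this assay, at which 3 of the 3 values shown sit. Among the measured compounds shown here, the one change that can be followed between measured compounds, hydrogen in place of acetyl on an oxygen on an aromatic ring, gives a step that the two limits leave unreadable from compound 1 to compound 2, so nothing about its size can be read.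

Compound 4 `CC(C)=CCc1cc(C(=O)Nc2cc3ccc(Cc4ccc(O)cc4)c(C)c3oc2=O)ccc1O` has not been measured. It differs from compound 2 in one place: 4-hydroxybenzyl in place of (4-methoxyphenyl)amino on an aromatic carbon. For the measured compounds named here, no measured step touches this kind of change, and the only measured step is itself unreadable, so there is nothing to carry over except that all three measured compounds sit at the limit.

On that basis compound 4 is expected to remain at the limit as well, with an estimated step of a number no higher from compound 2 to compound 4 (the limit leaves the size open) in this assay. The estimate for compound 4 is 100000 nM, within a range of 20000 nM to 300000 nM.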

Compound 4, half-maximal inhibitory concentration: 32100 nM
Compound 4: middle estimate off by 3.1-fold (0.49 log units), on the high side; the range from low to high includes it.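

On the aromatic carbon ortho to a methyl group, 4-hydroxybenzyl in place of (4-methoxyphenyl)amino gives, in this assay, an at least 3.1-fold lower number from compound 2 to compound 4 (0.49 log units; beyond the scatter), so this position can move the read-out on the shared core. This is the first step in the series whose size can be read at all, as the one earlier step remains unreadable and the other compounds give no number to compare: the limit of > 100000 nM in this assay, at which 3 of the 4 values shown sit.
The value of compound 2, > 100000 nM, is a limit of the assay, so the step is known only from one side.

The change alters two things at once, the nitrogen link to the aromatic ring becoming a carbon link and the methoxy end becoming a hydroxyl, and the compounds shown do not tell which of the two matters, or whether both do. They also leave open how other groups at this place would read in this assay, such as a plain amine, a carboxylic acid or a longer chain, and whether 4-hydroxybenzyl would have the same effect with the other aryl arm of compound 3.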